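The compounds below may be only part of what the source reports. "The series", "measured", "known", "first", "only" and "open" are said of these compounds alone.

Measured in a functional assay on MCF7 cells (Homo sapiens) for inhibition, read by radiometric assay and XTT assay; a higher number here means a weaker inhibitor, a lower number a stronger inhibitor:

- compound 1 `CCCC/C=C/C=C/[C@@]1(C)SC(O)=CC1=O`: 60 ug/mL
- compound 2 `CCCCCCCC[C@@]1(C)SC(O)=CC1=O`: 17.6 ug/mL
- compound 3 `CCCCCCCC[C@@]1(C)SC(O)=C(C)C1=O`: 48 ug/mL

In this assay, compound 3 gives 48 ug/mL, which cannot be told apart from the number for compound 1 at 60 ug/mL. Compound 2 at 17.6 ug/mL is clearly the stronger inhibitor of that pair.

Compound 4 `C=CCC1=C(O)S[C@](C)(CCCCCCCC)C1=O` differs from compound 3 in one place: vinyl in place of hydrogen on a saturated chain carbon bound to a double-bonded ring carbon. This is vinyl in place of hydrogen on a saturated chain carbon bound to a double-bonded ring carbon, so the methyl of compound 3 becomes allyl.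

For the measured compounds named here, only one measured step bears on this: a 2.7-fold higher number from compound 2 to compound 3 (0.44 log units; beyond the scatter), seen when methyl replaced hydrogen on a double-bonded ring carbon. That step was modest and raised the number. Going by the values given here, no measured compound carries a larger group there, so it is a thin guide. A small further rise is expected at most, probably not beyond the scatter. The expected change is a 1.3-fold higher number from compound 3 to compound 4 (0.10 log units; within the scatter). The estimate for compound 4 is 60 ug/mL, with an expected range of 25 ug/mL to 140 ug/mL.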

Compound 4, half-maximal inhibitory concentration: 44.4 ug/mL
For compound 4 the middle estimate is 1.4-fold (0.13 log units) above the measured one, within the range that was stated.
By their numbers in this assay, from the lowest: compound 2; then compounds 4, 3 and 1 (each within the scatter of the next).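

Swapping the methyl of compound 3 for the allyl of compound 4 gives numbers in this assay that cannot be told apart (a 1.1-fold lower number from compound 3 to compound 4 (0.03 log units; within the scatter)). Set against the hydrogen of compound 2, the allyl group still gives a weaker inhibitor (a 2.5-fold higher number from compound 2 to compound 4 (0.40 log units; beyond the scatter)), much as the methyl group did. So, among these three compounds, the clear difference lies between hydrogen and a carbon group at this position, while going from methyl to allyl adds nothing that can be detected, and no measurement here explains why.

Still open, on these data alone, is whether a different kind of group at this position, such as an amine, a carboxylic acid or a phenyl ring, would follow the same pattern. Also open, as far as these compounds go, is whether the allyl group would have the same effect on the core of compound 1, with its different chain.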